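The compounds below may be only part of what the source reports. "The series", "measured", "known", "first", "only" and "open" are said of these compounds alone.

Compound 1 `Fc1cc(Cl)ccc1-c1ccc(Cn2nnc3ccccc32)cn1` is the point of departure. Among the compounds with values here, in an ADME assay on microsomes from liver (Mus musculus, strain NMRI) for metabolic stability, tested at 2.5 uM (a lower number here means slower removal, a higher number faster removal of the compound), compound 1 gives 3.4 mL/min/g, and the only other compound of the set with a number is compound 3 `Fc1cc(Cl)ccc1-c1ccc(Cn2nnc3c(F)cccc32)cn1`, which in this assay gives 2.2 mL/min/g; the two numbers lie within the scatter of each other. Compound 2 `Fc1ccccc1-c1ccc(Cn2nnc3ccccc32)cn1` has no result in this assay: "not determined" (no result reported). The step to compound 4 `Fc1ccc2c(c1)nnn2Cc1ccc(-c2ccc(Cl)cc2F)nc1` is fluoro in place of hydrogen on an aromatic carbon. Within the data shown here, the one step that bears on it, a fluoro in place of hydrogen elsewhere on the core, is a 1.5-fold lower number from compound 1 to compound 3 (0.19 log units; within the scatter), so no change beyond the scatter is expected; the estimated step is a 1.2-fold lower number from compound 1 to compound 4 (0.07 log units; within the scatter). Compound 4 is therefore expected to give 2.9 mL/min/g, between 1.5 mL/min/g and 5.5 mL/min/g.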

Compound 4, intrinsic clearance in a liver preparation (reported as CLH), per the amount of preparation that the assay uses: 0.7 mL/min/g
The estimate for compound 4 lay 4.1-fold (0.62 log units) above the measured number; the whole stated range lies above it.
By their numbers in this assay, from the lowest: compound 4; then compounds 3 and 1 (each within the scatter of the next).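

In this assay, fluoro in place of hydrogen at this position gives a 4.9-fold lower number from compound 1 to compound 4 (0.69 log units; beyond the scatter) and so moves the number beyond the scatter, whereas the same exchange at the other position shown gives a 1.5-fold lower number from compound 1 to compound 3 (0.19 log units; within the scatter) and does not. Across these two steps, the outcome of this change depends on where on the shared core it is made. Nothing available here accounts for the difference.

From the compounds shown here alone, whether chloro, methoxy or a nitrile at this position would give a similar number remains open.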